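From 4-(methylsulfanyl)phenyl to 2-methoxyphenyl

A few compounds are considered here, and "the series" means these few. Any claim that something is new, unique, unknown or untested is made for them only; others in the source may bear on it.

Going by the values given here, in a functional assay on K562 cells (Homo sapiens) for antiproliferative activity, read by MTT assay, with a stated time of 72 h (a lower number here means a stronger inhibitor, a higher number a weaker inhibitor), compound 1 `COc1cc(C(=O)c2sc3ccccc3c2-c2ccc(C)cc2)cc(OC)c1OC` gives 3500 nM and compound 2 `COc1cc(C(=O)c2sc3ccccc3c2-c2ccc(SC)cc2)cc(OC)c1OC` gives 1800 nM, so compound 2 stands within the scatter of the only other number available. Compound 3 `COc1ccccc1-c1c(C(=O)c2cc(OC)c(OC)c(OC)c2)sc2ccccc12` brings a new change, 2-methoxyphenyl in place of 4-(methylsulfanyl)phenyl on an aromatic carbon. Among the compounds with values here, the only measured step, a 1.9-fold lower number from compound 1 to compound 2 (0.29 log units; within the scatter), stayed within the scatter, so no step beyond the scatter is expected in this assay, although this single step offers thin guidance. The expected change is a 1.6-fold higher number from compound 2 to compound 3 (0.19 log units; within the scatter). Compound 3 is estimated at 2800 nM, with an expected range of 900 nM to 9000 nM.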

Compound 3, half-maximal inhibitory concentration: 3400 nM
Compound 3: middle estimate off by 1.2-fold (0.08 log units), on the low side; the range from low to high includes it.
By their numbers in this assay, from the lowest: compounds 2, 3 and 1 (each within the scatter of the next).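

In this assay, replacing 4-(methylsulfanyl)phenyl with 2-methoxyphenyl gives a 1.9-fold higher number from compound 2 to compound 3 (0.28 log units; within the scatter), and replacing 4-methylphenyl with 2-methoxyphenyl gives a 1.0-fold lower number from compound 1 to compound 3 (0.01 log units; within the scatter). This position on the shared core has now carried three different substituted phenyl groups, and their numbers all lie within the scatter of one another, so neither change can be read as a real difference. No measurement shown here bears on why these groups read alike. On these data alone, it remains open whether a group other than a substituted phenyl at this position, such as an amine or a carboxylic acid, would give a step beyond the scatter.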